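The compounds below may be only part of what the source reports. "The series", "measured", "known", "first", "only" and "open" are said of these compounds alone.

Compound 1 `CCCCCCCCCCCCNc1nc(SCc2ccc(C(F)(F)F)cc2)nc2ccccc12` and compound 2 `FC(F)(F)c1ccc(CSc2nc(Nc3ccccc3C(F)(F)F)c3ccccc3n2)cc1` share the same core and differ only in the group carried on the ring nitrogen. In a functional assay on MDA-MB-231 cells (Homo sapiens) for cytotoxicity, read by MTT assay, with a stated time of 72 h (a lower number here means a stronger inhibitor, a higher number a weaker inhibitor), compound 1 gives > 50000 nM, which is a limit of the assay and not a number. Compound 2 gives > 50000 nM in this assay, again a limit and not a number. Among the measured compounds shown here, both results therefore sit at the limit of > 50000 nM in this assay, at which 2 of the 2 values shown sit, and nothing measured so far separates the two compounds. Compound 3 `FC(F)(F)c1ccc(CSc2nc(Nc3cccc(Cl)c3)c3ccccc3n2)cc1` brings one change: 3-chlorophenyl in place of 2-(trifluoromethyl)phenyl on a nitrogen on an aromatic ring. For the measured compounds named here, no measured pair shows what this change does in this assay, so the size of its step is unknown. The step from compound 2 to compound 3 is expected to be a step that the limit leaves unreadable from compound 2 to compound 3, a change not beyond the scatter. Compound 3 is therefore expected to give about 60000 nM in this assay, with a likely range from 20000 nM to 200000 nM, most probably reported again only as a limit.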

Compound 3, half-maximal inhibitory concentration: 18000 nM
The estimate for compound 3 lay 3.3-fold (0.52 log units) above the measured number; the whole stated range lies above it.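

Compound 3 is the first compound shown in this assay to give a measured number, so the group on this nitrogen can move the result away from the limit. Placing 3-chlorophenyl there in place of 2-(trifluoromethyl)phenyl gives an at least 2.7-fold lower number from compound 2 to compound 3 (0.44 log units; beyond the scatter), a change beyond the usual scatter. Compound 2 stands at a limit and not a number, so this step gives only the smallest size the change can have: the limit of > 50000 nM in this assay, at which 2 of the 3 values shown sit.

The two groups differ both in what the ring carries and in where it carries it, so the compounds shown cannot separate these two parts of the change. They also leave open how an unsubstituted phenyl ring, or a phenyl ring bearing an amine or a carboxylic acid, would behave on the same nitrogen.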